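A few compounds are considered here, and "the series" means these few. Any claim that something is new, unique, unknown or untested is made for them only; others in the source may bear on it.

Measured so far:
compound 1 `COc1ccc(C(c2ccc(OC(C)CN(C)C)cc2)c2cccc3ccccc23)c(OC)c1OC` — 13100 nM
compound 2 `COc1ccc(C(c2ccc(O)cc2)c2cccc3ccccc23)c(OC)c1OC` — 17500 nM
compound 3 `C=CCOC(c1ccc(OC)c(OC)c1OC)c1cccc2ccccc12` — > 20000 nM

All three were tested in a functional assay on MCF7 cells (Homo sapiens) for inhibition, read by sulforhodamine B assay, with a stated time of 48 h; a lower number here means a stronger inhibitor, a higher number a weaker inhibitor. Compound 1 gives 13100 nM. Compound 2 gives 17500 nM, and the change between them, a 1.3-fold higher number from compound 1 to compound 2 (0.13 log units; within the scatter), sits within the scatter. Among the compounds with values here, compound 3 is reported only as a limit, > 20000 nM, and not as a number; it is the one value of the three resting at that limit, as stated in the limit of > 20000 nM in this assay, at which 1 of the 3 values shown sits. The step to it, an at least 1.1-fold higher number from compound 2 to compound 3 (0.05 log units; that floor lies within the scatter), has a floor that also lies within the scatter.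

The next compound, compound 4 `COc1ccc(C(c2ccc(OCC(=O)O)cc2)c2cccc3ccccc23)c(OC)c1OC`, has not yet been measured. It differs from compound 3 in one place: 4-(carboxymethoxy)phenyl in place of allyloxy on a saturated chain carbon bound to two aromatic carbons. This change essentially reverses the step from compound 2 to compound 3, then adds a carboxymethyl to the oxygen on the entering phenyl. Within the data shown here, two measured steps bear on it. The step from compound 2 to compound 3 was within the scatter at its floor, and the step from compound 1 to compound 2, which also alters the group on that phenyl oxygen, was within the scatter. On that basis, the step expected for compound 4, an at least 1.2-fold lower number from compound 3 to compound 4 (0.09 log units; that floor lies within the scatter), is not beyond the scatter. Compound 4 is therefore estimated at 16000 nM, with a range from 7000 nM to 35000 nM.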

Compound 4, half-maximal inhibitory concentration: > 20000 nM
Compound 4: a limit, no number; the forecaster's own chance of this, stated with the estimate: 35%; at least 1.2-fold (0.09 log units) between middle value and limit.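

In this assay compound 4 gives > 20000 nM, which is a limit and not a number, and it is the second compound of this set to rest there: the limit of > 20000 nM in this assay, at which 2 of the 4 values shown sit.

Within the data shown here, this is the first result for a carboxylic acid on the oxygen of the phenyl ring: carboxymethyl in place of hydrogen gives an at least 1.1-fold higher number from compound 2 to compound 4 (0.05 log units; that floor lies within the scatter), and carboxymethyl in place of 1-((dimethylamino)methyl)ethyl gives an at least 1.5-fold higher number from compound 1 to compound 4 (0.18 log units; that floor lies within the scatter). Both steps are only floors, so the true gaps could be larger, but neither shows that the acid made a stronger inhibitor, and neither floor goes beyond the scatter; the step from compound 3 to compound 4 cannot be read, since both ends are limits.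

As far as these compounds go, how far compound 3 and compound 4 lie past the limit stays unknown, so the swap of allyloxy for 4-(carboxymethoxy)phenyl on the saturated chain carbon has no measured size. Also open, from the compounds shown here alone, is whether a plain methyl or a longer chain ending in an amide, placed on that same oxygen, would give a number clear of the limit and of the scatter around compound 1 and compound 2.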